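The source may report more compounds than this note shows. Statements on the series, on what has been measured and on what is new or still open speak of the compounds shown alone.

Compound 3, `Fc1ccc(Cc2ccc3c(NCCCNCc4ccco4)ccnc3c2)cc1`, is the point of departure. In an ADME assay for permeability, using PAMPA, with a stated time of 30 min, at pH 7.4 (a higher number here means that the compound crosses the layer faster, a lower number that the compound crosses the layer more slowly), compound 3 gives 23 10^-6 cm/s, level at the digits shown with compound 1, `CC(C)CCc1ccc2c(NCCCNCc3ccco3)ccnc2c1`, which in this assay gives 23 10^-6 cm/s; together the two are the lowest of the three numbers measured. Compound 2, `COc1ccc(Oc2ccc3c(NCCCNCc4ccco4)ccnc3c2)cc1`, sits far above them: in this assay compound 2 gives 317 10^-6 cm/s, and the step shows a 14-fold lower number from compound 2 to compound 3 (1.14 log units; beyond the scatter), matching a 14-fold higher number from compound 1 to compound 2 (1.14 log units; beyond the scatter) in size.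

The next compound is compound 4, `c1ccc(Cc2ccc3c(NCCCNCc4ccco4)ccnc3c2)cc1`, which has not been measured. Its difference from compound 3 is hydrogen in place of fluoro on an aromatic carbon. Going by the values given here, none of the measured steps removes a fluorine; the nearest analogy is no change at the digits printed from compound 1 to compound 3 (within the scatter), where a group carrying the 4-fluorophenyl came in for isobutyl without shifting the number, while the two large steps both involve the 4-methoxyphenoxy group of compound 2 and do not bear on this change. Among the compounds with values here, with no measured step touching the fluorine, compound 4 is expected to stay close to compound 3, and the step from compound 3 to compound 4 is estimated as no change at the digits printed from compound 3 to compound 4 (within the scatter), within the scatter. On that basis compound 4 is estimated at 23 10^-6 cm/s in this assay, with a range from 10 10^-6 cm/s to 50 10^-6 cm/s.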

Compound 4, apparent permeability: 23 10^-6 cm/s
Beside the measured number, compound 4's estimate shows no gap at the digits printed; the range from low to high includes it.
By their numbers in this assay, from the lowest: compounds 1, 3 and 4 (each within the scatter of the next); then compound 2.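

In this assay the fluoro on the aromatic carbon, para to a large group, gives way to hydrogen with no change at the digits printed from compound 3 to compound 4 (within the scatter) in this pair, the only pair shown that isolates this atom. The large gap to compound 2 remains without the fluorine: benzyl in place of 4-methoxyphenoxy gives a 14-fold lower number from compound 2 to compound 4 (1.14 log units; beyond the scatter) in this comparison, the same size as the step to the 4-fluorobenzyl compound, while phenyl in place of isobutyl gives no change at the digits printed from compound 1 to compound 4 (within the scatter) on the saturated chain carbon, so the isopentyl compound and the benzyl compound stand together whether or not the fluorine is present. No supporting measurement is available to explain why this number holds or why compound 2 stands apart.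

Hydrogen and fluoro are the only two groups compared on this aromatic carbon, so a methoxy, an amine or a carboxylic acid there remains an open case. From the compounds shown here alone, it is also open whether the high number of compound 2 goes with the oxygen link or with the methoxy, a question that a phenoxy group and a 4-methoxybenzyl group on the shared core would separate.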